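Swapping the Amide Aryl Group on a Shared Core

The source may report more compounds than this note shows. Statements on the series, on what has been measured and on what is new or still open speak of the compounds shown alone.

Of the compounds shown here, two built on the same core have been tested so far. Compound 1 `CN1[C@@H]2c3[nH]c4ccccc4c3C[C@H]1[C@H](C#N)N1[C@@H](CN3C(=O)c4ccccc4C3=O)c3[nH]c4ccccc4c3C[C@@H]21` and compound 2 `CN1[C@@H]2c3[nH]c4ccccc4c3C[C@H]1[C@H](C#N)N1[C@@H](CNC(=O)c3cccc4c3CCCC4)c3[nH]c4ccccc4c3C[C@@H]21` differ in the group attached through the side chain on the core. In a functional assay on MCF7 cells (Homo sapiens) for cytotoxicity, read by MTT assay, with a stated time of 72 h (on this read-out higher numbers stand for weaker inhibition and lower numbers for stronger inhibition), compound 1 gives 610 nM, and compound 2 gives 4470 nM. Compound 2 thus stands as the higher of the two numbers, and the gap to compound 1 is beyond the usual scatter, so compound 2 is the weaker of the pair.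

Compound 3 `CN1[C@@H]2c3[nH]c4ccccc4c3C[C@H]1[C@H](C#N)N1[C@@H](CNC(=O)/C=C/c3cccc(C(F)(F)F)c3)c3[nH]c4ccccc4c3C[C@@H]21` keeps the core and the amide of compound 2 but changes the group on the amide carbonyl: 2-(3-(trifluoromethyl)phenyl)ethenyl in place of 1,2,3,4-tetrahydronaphthalen-5-yl on a carbonyl carbon. Within the data shown here, no measured pair shows this particular exchange, so there is nothing to read a step size from. With compound 2 standing as the weakest number seen, the expected step of a 1.5-fold lower number from compound 2 to compound 3 (0.17 log units; within the scatter) is small and toward slightly stronger inhibition, though it may well stay within the scatter. In this assay compound 3 is therefore estimated at 3000 nM, with a range from 800 nM to 10000 nM.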

Compound 3, half-maximal inhibitory concentration: 110 nM
Compound 3: the middle estimate sits 27-fold (1.44 log units) above what was measured; the measured number lies below the stated range.
By their numbers in this assay, from the lowest: compound 3; then compound 1; then compound 2.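

The group on the carbonyl carbon of the amide has a strong influence on the result in this assay: with the rest of compound 2 kept, putting 2-(3-(trifluoromethyl)phenyl)ethenyl in place of 1,2,3,4-tetrahydronaphthalen-5-yl gives a 41-fold lower number from compound 2 to compound 3 (1.61 log units; beyond the scatter) and so moves the number far beyond the scatter. Among these compounds, this is the first step that can be read as a single exchange, and it shows that this position is sensitive to what sits there and that the change can lead toward stronger inhibition. The exchange alters several features at once, as it removes the non-aromatic ring and adds a double bond outside aromatic rings and three fluorine atoms, and nothing available here bears on why the number moved.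

The compounds shown leave open which of these features accounts for the step: a plain 2-phenylethenyl group or a saturated 2-(3-(trifluoromethyl)phenyl)ethyl group on the same carbonyl would begin to separate them. From the compounds shown here alone, it also remains open how an amine or a carboxylic acid on the aromatic ring would fare at this position.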